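The compounds below may be only part of what the source reports. "The series", "measured", "known", "first", "only" and "open" are said of these compounds alone.

Measured in an ADME assay on MT4 cells (Homo sapiens) for cytotoxicity, read by MTT assay, with a stated time of 5 days; a higher number here means that more compound is tolerated, a lower number that less compound is tolerated:
Compound 1 `O=C1N(Cc2ccc(Cl)cc2Cl)c2cccn2S(=O)(=O)N1Cc1ccccc1`: 218000 nM
Compound 2 `O=C1N(Cc2ccccc2)c2cccn2S(=O)(=O)N1Cc1cccc(F)c1`: > 288000 nM, a limit and not a number
Compound 3 `CC(C)=CCN1C(=O)N(Cc2ccccc2)S(=O)(=O)n2cccc21`: 226000 nM

Compound 2 has no number and sits on (the limit of > 288000 nM in this assay, at which 1 of the 3 values shown sits).

Compound 4 `O=C1N(Cc2ccccc2Cl)c2cccn2S(=O)(=O)N1Cc1cccc(F)c1` follows from compound 2 by chloro in place of hydrogen on an aromatic carbon, turning benzyl into 2-chlorobenzyl. Going by the values given here, one measured step bears on this, though only loosely: a 1.0-fold higher number from compound 1 to compound 3 (0.02 log units; within the scatter). There a 2,4-dichlorophenyl group leaves, and the size of the step stays within the scatter. No step beyond the scatter is therefore expected in this assay. The estimated step is an at least 1.2-fold lower number from compound 2 to compound 4 (0.07 log units; that floor lies within the scatter), and any move is expected to be downward. For compound 4 the estimate is 240000 nM, with an expected range of 140000 nM to 340000 nM.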

Compound 4, half-maximal cytotoxic concentration: 231000 nM
For compound 4 the middle estimate is 1.0-fold (0.02 log units) above the measured one; low and high end bracket the measured number.
By their numbers in this assay, from the lowest: compounds 1, 3 and 4 (each within the scatter of the next). At a limit, above all of these: compound 2.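

In this assay, a single chloro on an aromatic carbon, ortho to a large group, turns benzyl into 2-chlorobenzyl and gives an at least 1.2-fold lower number from compound 2 to compound 4 (0.09 log units; that floor lies within the scatter). Going by these compounds alone, this is the first step in which one atom alone changes on this benzyl group, and only its floor can be read. Compound 2 carries a limit and not a number: the limit of > 288000 nM in this assay, at which 1 of the 4 values shown sits.

From the compounds shown here alone, the true size of this step stays open. So does whether an amine or a carboxylic acid at the same place would move the number in this assay beyond the scatter.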